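The compounds below may be only part of what the source reports. "The series", "measured", "known", "first", "only" and "open" are said of these compounds alone.

Of the compounds shown here, two built on one shared core have been tested in a functional assay on the whole organism (strain AKR) for inhibition, with Mus musculus as the target, read by paw edema, with a stated time of 3.5 h, at a dose of 0.01 mmol/kg by the intraperitoneal route; on this read-out higher numbers stand for more inhibition at the one dose given (going by the name of the read-out) and lower numbers for less inhibition. Compound 1 `O=C1N/C(=N\c2nccs2)S/C1=C\c1cccc(O)c1` gives 33.7% in this assay. Compound 2 `COc1ccccc1/C=C1\S/C(=N/c2nccs2)NC1=O` gives 50% in this assay, the highest of the two numbers, and its gap to compound 1 lies beyond the usual scatter of repeated measurements. Compound 3 `COc1ccc(OC)c(/C=C2\S/C(=N/c3nccs3)NC2=O)c1` has not yet been measured. It differs from compound 2 in a single place: methoxy in place of hydrogen on an aromatic carbon. Among the measured compounds shown here, no pair of measured compounds shows what such a change does to the read-out, so the direction of the step from compound 2 to compound 3 cannot be read from the data. The step of no change at the digits printed from compound 2 to compound 3 (within the scatter) is expected to be small, in either direction, and not clearly beyond the scatter. Compound 3 is estimated at 50%, with a range from 30% to 65%.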

Compound 3, a percentage reported as inhibition, in the whole organism at one dose (the size of the read-out at that dose, not a potency): 26%
Estimate against measurement, compound 3: 24 percentage points above; the whole stated range lies above it.
By their numbers in this assay, from the lowest: compounds 3 and 1 (each within the scatter of the next); then compound 2.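

Putting methoxy in place of hydrogen on this aromatic carbon, meta to a large group and para to a methoxy group, gives a number 24 percentage points lower from compound 2 to compound 3 (beyond the scatter) in this assay. Among the compounds shown here, this is the first measured pair that differs in one place, and it shows that this position is not indifferent to substitution: here, the added methoxy lowers inhibition at the one dose given. The data offer no measurement that would account for this step.

The compounds shown leave open whether fluorine, an amine or a carboxylic acid at this same carbon would lower the read-out as methoxy does, or leave it unchanged. They also leave open whether methoxy has the same effect on the other carbons of this ring.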